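Anilide series: chloro for ethoxy on the aryl amide

This account rests on a few compounds, and the source may have more. Where it says the series, first, only, none or still open, it means among the compounds named here.

Compound 1 `O=C(Nc1ccc(OC(F)F)cc1)c1cccc(/C=C2\CC(=O)N(c3ccccc3)C2=O)c1` gives > 100000 nM, which is an assay limit rather than a number. For the measured compounds named here, in an ADME assay on HCT-116 cells (Homo sapiens) for cytotoxicity, read by MTT assay, with a stated time of 72 h (a lower number here means a stronger inhibitor, a higher number a weaker inhibitor), compound 2 `CCOc1ccc(NC(=O)c2cccc(/C=C3\CC(=O)N(Cc4ccccc4)C3=O)c2)cc1` gives 41700 nM, the only numeric value in hand; the other sits at the limit of > 100000 nM in this assay, at which 1 of the 2 values shown sits. Compound 3 `O=C(Nc1ccc(Cl)cc1)c1cccc(/C=C2\CC(=O)N(Cc3ccccc3)C2=O)c1` differs from compound 2 by chloro in place of ethoxy on an aromatic carbon. Going by the values given here, no measured step shows how this position responds, so the change is expected to stay within the usual scatter, a 1.2-fold lower number from compound 2 to compound 3 (0.08 log units; within the scatter). Compound 3 is accordingly estimated at 35000 nM, within a range from 12000 nM to 100000 nM.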

Compound 3, half-maximal inhibitory concentration: > 100000 nM
Compound 3 was reported as a limit; the forecaster's own chance of this, stated with the estimate: 25%; at least 2.8-fold (0.45 log units) between middle value and limit.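

In this assay this position proves responsive rather than silent: chloro in place of ethoxy, para to a large group, gives an at least 2.3-fold higher number from compound 2 to compound 3 (0.37 log units; beyond the scatter). Compound 3 stands at an assay limit rather than a number, so the step has a lower bound but no known size: the limit of > 100000 nM in this assay, at which 2 of the 3 values shown sit. For the compounds shown here, the ethoxy of compound 2 therefore goes with the only numeric value.

Open, as far as these compounds go, is whether a longer alkoxy chain, an amine or a carboxylic acid at this position would give a lower number than ethoxy.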